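The source may hold more compounds than are shown below. What is called first, only, known or untested is meant among the compounds shown, and "the series" means these compounds.

Among the measured compounds shown here, compound 2, `C/C(=C\c1cc(-c2ccc(F)cc2)cs1)C(N)=O`, gives the lowest of the two numbers so far in a functional assay on MCF7 cells (Homo sapiens) for cytotoxicity, read by CCK-8 assay, with a stated time of 24 h; on this read-out lower numbers stand for stronger inhibition and higher numbers for weaker inhibition: compound 2 gives 1440 nM. Its nearest neighbour, compound 1, `C/C(=C\c1cc(-c2ccccc2)cs1)C(N)=O`, gives 2680 nM in this assay; that single step, fluoro in place of hydrogen on an aromatic carbon, is a 1.9-fold lower number from compound 1 to compound 2 (0.27 log units; within the scatter). Compound 3, `C/C(=C\c1cc(-c2ccc(C#N)cc2)cs1)C(N)=O`, differs from compound 2 by cyano in place of fluoro on an aromatic carbon. No measured step swaps one group for another at this position, and the only step shown stays within the scatter, so no shift beyond the scatter is expected here. The expected step from compound 2 to compound 3 is a 1.1-fold lower number from compound 2 to compound 3 (0.04 log units; within the scatter). Compound 3 is therefore estimated at 1300 nM in this assay, within a range of 500 nM to 3500 nM.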

Compound 3, half-maximal inhibitory concentration: 240 nM
Beside the measured number, compound 3's estimate is 5.4-fold (0.73 log units) above it, outside the stated range (below it).
By their numbers in this assay, from the lowest: compound 3; then compounds 2 and 1 (each within the scatter of the next).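

In this assay, this position turns out to be able to shift the number beyond the scatter: cyano in place of fluoro gives a 6.0-fold lower number from compound 2 to compound 3 (0.78 log units; beyond the scatter), and cyano in place of hydrogen gives an 11-fold lower number from compound 1 to compound 3 (1.05 log units; beyond the scatter). Fluoro in place of hydrogen had stayed within the scatter, so the choice of group here does matter, and among these compounds cyano stands apart. Nothing shown explains why cyano differs from fluoro here. From the compounds shown here alone, whether the shift is particular to cyano remains open, since an amine, a carboxylic acid or a methoxy group at this position would test that.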